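Side-chain shortening in the shared-core series

The compounds below may be only part of what the source reports. "The series", "measured", "known", "first", "only" and "open" are said of these compounds alone.

Measured so far:
compound 1, `COc1ccc(Cc2cnc(CCc3ccc(-c4ccccc4C(=O)O)cc3)[nH]2)cc1`: 5360 nM
compound 2, `CCCCc1cnc(C(CCCC)Cc2ccc(-c3ccccc3C(=O)O)cc2)[nH]1`: 2660 nM

In an in vitro functional assay on cells for agonist activity at Bombesin receptor subtype-3 (Homo sapiens), read by luminescence and calcium flux (a higher number here means that more compound is needed for the effect, a lower number that less compound is needed), compound 2 has the lower of the two numbers; compound 1 stands a step away that remains within the scatter, so no order between the two can be read. Compound 3 is `CCCCc1cnc(C(CC)Cc2ccc(-c3ccccc3C(=O)O)cc2)[nH]1`, not yet measured. It is compound 2 with hydrogen in place of ethyl on a saturated chain carbon, three bonds along the chain from an aromatic carbon; cut one bond further out, the same change reads butyl to ethyl. Within the data shown here, no measured pair so far differs in one place, so the size of this kind of step cannot be taken from a measured example. The step of a 1.5-fold higher number from compound 2 to compound 3 (0.18 log units; within the scatter) is estimated to be small, toward a higher number, and possibly not beyond the scatter. Compound 3 is expected at 4000 nM, with a range from 1500 nM to 12000 nM.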

Compound 3, half-maximal effective concentration: 2720 nM
Estimate against measurement, compound 3: 1.5-fold (0.17 log units) above, within the range that was stated.
By their numbers in this assay, from the lowest: compounds 2, 3 and 1 (each within the scatter of the next).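

In this assay, among these compounds, this is the first one-place step available: a 1.0-fold higher number from compound 2 to compound 3 (0.01 log units; within the scatter). Butyl to ethyl on this saturated chain carbon, three bonds along the chain from an aromatic carbon, therefore gives no readable change, and the two chain lengths cannot be told apart in this read-out. No measurement at hand bears on why the number stays within the scatter.

Still open, on these data alone, is whether a group of another kind on this carbon, such as an amine or a carboxylic acid, or a chain longer than butyl, would give a step beyond the scatter. Also open, as far as these compounds go, is whether butyl to ethyl reads the same when other groups are carried elsewhere on the shared core.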